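Dichloropurine to monochloropurine: expected cytotoxicity of compound 3

This account rests on a few compounds, and the source may have more. Where it says the series, first, only, none or still open, it means among the compounds named here.

Measured so far:
compound 1 `ClCc1ccc(Cn2cnc3c(Cl)ncnc32)cc1` — > 100000 nM
compound 2 `ClCc1ccccc1Cn1cnc2c(Cl)nc(Cl)nc21` — "not determined" (no result reported)

Compound 2 `ClCc1ccccc1Cn1cnc2c(Cl)nc(Cl)nc21` stands without a number on the cytotoxicity read-out: in a functional assay on OVCAR-4 cells (Homo sapiens) for cytotoxicity, read by sulforhodamine B assay, with a stated time of 48 h (on this read-out lower numbers stand for higher toxicity in this test and higher numbers for lower toxicity in this test), compound 2 is recorded as "not determined" (no result reported), so no result exists. Among the measured compounds shown here, the only value from the set is a limit. In this assay compound 1 gives > 100000 nM, and that is a limit of the test rather than a number (the limit of > 100000 nM in this assay, at which 1 of the 2 values shown sits). Compound 1 thus shows no measurable cell kill up to the top of the tested range.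

Compound 3 `ClCc1ccccc1Cn1cnc2c(Cl)ncnc21` is the next member. It differs from compound 2 by hydrogen in place of chloro on an aromatic carbon. For the measured compounds named here, no measured pair shows how this change moves the read-out, and compound 2 itself has no number, so no direction can be taken from a step. Compound 3 is instead a positional isomer of compound 1, differing only in the placement of the chloromethyl substituent, and compound 1 sits at the limit.

On that basis compound 3 is expected to sit at or near the limit as well, with an estimated value of 100000 nM (range 30000 nM to 300000 nM).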

Compound 3, concentration lethal to 50% of the cells: 45700 nM
Compound 3: the middle estimate sits 2.2-fold (0.34 log units) above what was measured; the measured number falls inside the stated range.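

No step can be read between compound 2 and compound 3: compound 2 has no number in this assay, where compound 3 gives 45700 nM. The compounds shown leave open how hydrogen in place of chloro on an aromatic carbon moves the read-out in this assay.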